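Aryl swaps on the amide carbonyl: a flat series

The compounds below may be only part of what the source reports. "The series", "measured", "known", "first", "only" and "open" are said of these compounds alone.

Values in a functional assay on HeLa cells (Homo sapiens) for antiproliferative activity, read by MTT assay, with a stated time of 24 h; a lower number here means a stronger inhibitor, a higher number a weaker inhibitor:
- compound 1 `COC(=O)c1scc(-c2ccc(NC(=O)c3ccc4ccccc4c3)cc2)c1OC`: 18200 nM
- compound 2 `COC(=O)c1scc(-c2ccc(NC(=O)c3cccc(C(F)(F)F)c3)cc2)c1OC`: 19300 nM
- compound 3 `COC(=O)c1scc(-c2ccc(NC(=O)c3ccc(F)c(Cl)n3)cc2)c1OC`: 16200 nM

Compound 3 stands level with the other two: a 1.1-fold lower number from compound 1 to compound 3 (0.05 log units; within the scatter), and a 1.2-fold lower number from compound 2 to compound 3 (0.08 log units; within the scatter). The next change leads to compound 4 `COC(=O)c1scc(-c2ccc(NC(=O)c3ccc(C(F)(F)F)cc3)cc2)c1OC`, with 4-(trifluoromethyl)phenyl in place of 6-chloro-5-fluoropyridin-2-yl on a carbonyl carbon. The second step above bears most closely, since it also exchanged a trifluoromethyl-bearing phenyl for this pyridinyl group. The remaining swap at the same carbon, a 1.1-fold higher number from compound 1 to compound 2 (0.03 log units; within the scatter), was equally small. For the measured compounds named here, no measured compound goes against this flatness, though the set is small. No step beyond the scatter is therefore expected in this assay, and the expected step is a 1.1-fold higher number from compound 3 to compound 4 (0.05 log units; within the scatter). Compound 4 is estimated at 18000 nM, with an expected range of 10500 nM to 31000 nM.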

Compound 4, half-maximal inhibitory concentration: 14400 nM
The estimate for compound 4 lay 1.3-fold (0.10 log units) above the measured number; low and high end bracket the measured number.
By their numbers in this assay, from the lowest: compounds 4, 3, 1 and 2 (each within the scatter of the next).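

In this assay, 4-(trifluoromethyl)phenyl on the carbonyl carbon stays level with the other aryl groups, with a 1.1-fold lower number from compound 3 to compound 4 (0.05 log units; within the scatter) and a 1.3-fold lower number from compound 1 to compound 4 (0.10 log units; within the scatter) as its steps. New here is a pair differing only in where the trifluoromethyl sits on the phenyl ring, and a 1.3-fold lower number from compound 2 to compound 4 (0.13 log units; within the scatter) shows that this difference does not separate the two compounds. Nothing measured here explains the flatness.

Still open, on these data alone, is whether any group at this carbon gives a step beyond the scatter. A saturated group carrying an amine or a carboxylic acid, in place of the aryl ring, would test this.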